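The compounds below may be only part of what the source reports. "The series", "measured", "known", "first", "only" and "open" are said of these compounds alone.

Compound 1 `Cc1cc(COc2ccccc2)nc(-c2ccccn2)n1`: 794 nM
Compound 2 `Cc1cc(COc2ccccc2S(C)(=O)=O)nc(-c2ccccn2)n1`: > 39800 nM

Among the measured compounds shown here, in a functional assay on cells for antagonist activity at Free fatty acid receptor 1 (Homo sapiens), read by TR-FRET and inositol phosphate accumulation, with a stated time of 2 h (on this read-out lower numbers stand for stronger inhibition and higher numbers for weaker inhibition), compound 1 gives 794 nM, the only outright number among the two values shown. The value for compound 2 is a limit of this assay, not a number (the limit of > 39800 nM in this assay, at which 1 of the 2 values shown sits). Compound 3 `Cc1cc(COc2cccc(S(C)(=O)=O)c2)nc(-c2ccccn2)n1` differs from compound 1 by methylsulfonyl in place of hydrogen on an aromatic carbon. For the measured compounds named here, one measured step bears on this change: an at least 50-fold higher number from compound 1 to compound 2 (1.70 log units; beyond the scatter), where the same methylsulfonyl group entered the same ring of compound 1. That step went far beyond the scatter, so a large weakening is the expected direction for compound 3 as well, though its size at this new place is uncertain and could stay short of the limit. The step expected is a 13-fold higher number from compound 1 to compound 3 (1.10 log units; beyond the scatter). Compound 3 is therefore estimated at 10000 nM, with a range from 2000 nM to 50000 nM.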

Compound 3, half-maximal inhibitory concentration: > 39800 nM
Compound 3: a limit, no number; the forecaster's own chance of this, stated with the estimate: 35%; middle value at least 3.9-fold (0.59 log units) away from the limit.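

In this assay, methylsulfonyl in place of hydrogen on an aromatic carbon meta to a large group gives an at least 50-fold higher number from compound 1 to compound 3 (1.70 log units; beyond the scatter), so the large loss seen with compound 2 is not confined to a single place on this ring. Going by these compounds, the value of compound 3, > 39800 nM, is a limit of the assay and not a number, so the full size of this step stays unknown. With compound 2 at that same limit, the two places cannot be ranked against each other: the limit of > 39800 nM in this assay, at which 2 of the 3 values shown sit.

On these data alone, it remains open whether a methoxy group, an amine or a carboxylic acid on this ring would keep the inhibition of compound 1 at 794 nM. The compounds shown also leave open how methylsulfonyl would fare on another part of the shared core.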